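This account rests on a few compounds, and the source may have more. Where it says the series, first, only, none or still open, it means among the compounds named here.

Measured so far:
- Compound 1 `O=[N+]([O-])c1cccc2c1CCN(c1ncnc3c1ncn3[C@@H]1O[C@H](CO)[C@@H](O)[C@H]1O)C2`: 3020 nM
- Compound 2 `CCCCCNc1ncnc2c1ncn2[C@@H]1O[C@H](CO)[C@@H](O)[C@H]1O`: 13500 nM
- Compound 3 `Nc1ncnc2c1ncn2[C@@H]1O[C@H](COCCOCCNc2ncnc3c2ncn3[C@@H]2O[C@H](CO)[C@@H](O)[C@H]2O)[C@@H](O)[C@H]1O`: 912000 nM

In an assay on isolated protein for binding affinity to Equilibrative nucleoside transporter 1 (Homo sapiens) (a lower number here means a stronger inhibitor, a higher number a weaker inhibitor), compound 2 gives 13500 nM, the second highest of the three numbers. Compound 1 gives 3020 nM, a lower number that lies beyond the usual scatter, and compound 3 gives 912000 nM, a far higher number, also beyond the scatter. Among the compounds with values here, none of these three pairs differs in only one place, so no single step between measured compounds can be read off.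

Compound 4 `OC[C@H]1O[C@@H](n2cnc3c(OCc4ccccc4)ncnc32)[C@H](O)[C@@H]1O` has not yet been measured. It differs from compound 2 in one place: benzyloxy in place of pentylamino on an aromatic carbon. The chain with its amine hydrogen is gone, and a group carrying a benzene ring takes its place on the shared core.

Within the data shown here, nothing among the measured compounds directly tracks this exchange. Among the measured compounds shown here, the only hint comes from compound 1, which also carries an aromatic ring and gives 3020 nM, a lower number than compound 2. A moderate move toward a lower number is therefore expected, with wide uncertainty. The expected step is a 3.4-fold lower number from compound 2 to compound 4 (0.53 log units; beyond the scatter) in this assay. For compound 4 the estimate is 4000 nM, with a range from 600 nM to 25000 nM.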

Compound 4, half-maximal inhibitory concentration: 2090 nM
Compound 4: the middle estimate sits 1.9-fold (0.28 log units) above what was measured; the measured number falls inside the stated range.
By their numbers in this assay, from the lowest: compounds 4 and 1 (each within the scatter of the next); then compound 2; then compound 3.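

In this assay, within the data shown here, exchanging pentylamino for benzyloxy on this aromatic carbon of the shared core gives a 6.5-fold lower number from compound 2 to compound 4 (0.81 log units; beyond the scatter), the first step in this set that can be read for a change in one place. It shows that the number responds to the group at this position, and that a stronger inhibitor can be reached here with a group that carries no hydrogen-bond donor, so the amine hydrogen of pentylamino is not needed for this level of inhibition. Among these compounds, nothing measured explains the step, and the single exchange alters the linking atom, the donor count and the chain-or-ring character together, so the step cannot be divided among them.

The compounds shown leave open which of these differences carries the step: benzylamino would pair the benzene ring with a nitrogen link, while pentyloxy would pair the open chain with an oxygen link. Also open, on these data alone, is whether a methoxy group or a chlorine on the benzene ring, or a longer chain between that ring and the oxygen, would move the number further.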